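From 3-Nitrophenyl to 2-Methoxyphenyl, a Step Between Limits

A few compounds are considered here, and "the series" means these few. Any claim that something is new, unique, unknown or untested is made for them only; others in the source may bear on it.

Compound 1 `Cc1ccc(S(=O)(=O)N2CC3(C[C@H]2C(=O)NN)SCCS3)cc1` and compound 2 `Cc1ccc(S(=O)(=O)N2CC3(C[C@H]2C(=O)N/N=C/c2cccc([N+](=O)[O-])c2)SCCS3)cc1` share one core, and both have been measured in a functional assay on C8166 cells (Homo sapiens) for cytotoxicity, read by MTT assay, with a stated time of 72 h; a lower number here means that less compound is tolerated, a higher number that more compound is tolerated. Compound 1 gives > 519000 nM, which is a limit and not a number. Compound 2 gives > 395000 nM, which is likewise a limit. Compound 2 therefore stands without a numerical value, and the only other result available to compare it with is also a limit.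

Compound 3 `COc1ccccc1/C=N/NC(=O)[C@@H]1CC2(CN1S(=O)(=O)c1ccc(C)cc1)SCCS2` keeps the core of compound 2 and changes one group: 2-methoxyphenyl in place of 3-nitrophenyl on a carbon with a double bond to nitrogen. In words, 2-methoxyphenyl replaces 3-nitrophenyl on a carbon with a double bond to nitrogen.

Going by the values given here, the one measured step that bears on this change is a step that the two limits leave unreadable from compound 1 to compound 2. Its size cannot be read, so it offers no measure for the new change and no direction. No shift beyond the usual scatter is therefore expected in this assay. The expected result is a step that the limit leaves unreadable from compound 2 to compound 3. Compound 3 is estimated at 405000 nM, with an expected range from 150000 nM to 600000 nM, and it will most likely be reported as a limit too.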

Compound 3, half-maximal cytotoxic concentration: 388000 nM
Beside the measured number, compound 3's estimate is 1.0-fold (0.02 log units) above it, and the stated range covers the measured number.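

In this assay, going by these compounds alone, compound 3 gives the first result of the three that is a number and not a limit, so 2-methoxyphenyl on a carbon with a double bond to nitrogen gives a readable end point where the earlier compounds gave none. Set against 3-nitrophenyl, the change of group gives an at least 1.0-fold lower number from compound 2 to compound 3 (0.00 log units; that floor lies within the scatter), so it cannot be told apart from no change at all. Set against the unsubstituted amide-type nitrogen of the shared core, the whole added group gives an at least 1.3-fold lower number from compound 1 to compound 3 (0.12 log units; that floor lies within the scatter), which is again only a floor and again cannot show a real gap.

From the compounds shown here alone, the step from compound 1 to compound 2 cannot be read, and how far compound 2 really lies from compound 3 stays open, as compound 2 is held by a limit: the limit of > 395000 nM in this assay, at which 1 of the 3 values shown sits. Going by these compounds, it also stays open whether a phenyl ring carrying an amine or a carboxylic acid, or a longer chain, in place of 2-methoxyphenyl would give a number in the same region.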